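The source may hold more compounds than are shown below. What is called first, only, known or untested is meant among the compounds shown, and "the series" means these compounds.

Compound 2 `COc1ccc(CNc2nc(SC)nc3ncccc23)cc1` stands at the highest of the two numbers recorded so far: in an ADME assay on 184B5 cells (Homo sapiens) for cytotoxicity, read by MTT assay, with a stated time of 72 h (on this read-out lower numbers stand for stronger inhibition of growth and higher numbers for weaker inhibition of growth), compound 2 gives 34200 nM, while compound 1 `[SeH]c1nc(NCc2ccccc2)c2cccnc2n1` gives 3700 nM in this assay, a gap beyond the usual scatter. Compound 3 `CSc1nc(NCc2ccccc2)c2cccnc2n1` differs from compound 2 by hydrogen in place of methoxy on an aromatic carbon. Going by the values given here, no measured pair shows this change on its own, so the expected step is a 2.3-fold lower number from compound 2 to compound 3 (0.36 log units; beyond the scatter), toward a lower number, an expectation resting on compound 1 giving 3700 nM without a methoxy. Compound 3 is estimated at 15000 nM, within a range from 4000 nM to 50000 nM.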

Compound 3, concentration for 50% growth inhibition: 49000 nM
Estimate against measurement, compound 3: 3.3-fold (0.51 log units) below, and the stated range covers the measured number.
By their numbers in this assay, from the lowest: compound 1; then compounds 2 and 3 (each within the scatter of the next).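

Hydrogen in place of methoxy on an aromatic carbon, para to a large group, leaves the number in this assay within the scatter (a 1.4-fold higher number from compound 2 to compound 3 (0.16 log units; within the scatter)), so this place shows no measurable response to the change so far. The large step lies elsewhere: the group of 2 heavy atoms in place of the selenium atom gives (a 13-fold higher number from compound 1 to compound 3 (1.12 log units; beyond the scatter)). Nothing measured here accounts for the size of either step. Still open, on these data alone, is whether an amine or a carboxylic acid at the methoxy place would move the number, and whether the selenium atom keeps its lower number alongside a methoxy.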